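A few compounds are considered here, and "the series" means these few. Any claim that something is new, unique, unknown or untested is made for them only; others in the source may bear on it.

Values in a functional assay on SW480 cells (Homo sapiens) for antiproliferative activity, read by CCK-8 assay and cell counting, with a stated time of 72 h; on this read-out lower numbers stand for stronger inhibition and higher numbers for weaker inhibition
Compound 1 `O=C(Nc1ccccc1OC(=O)c1ccc(CCl)cc1)c1ccc(CCl)cc1` gives 6900 nM
Compound 2 `O=C(Nc1cccc(OC(=O)c2ccc(CO[N+](=O)[O-])cc2)c1)c1ccc(CO[N+](=O)[O-])cc1` gives 8400 nM
Compound 3 `O=C(Nc1ccccc1)c1ccc(CCl)cc1` gives 900 nM

Compound 3 (900 nM) has the lowest of the three numbers and is the most potent of the set, with its gaps to compound 1 and compound 2 both beyond the scatter. The next entry is compound 4 `O=C(Nc1ccccc1)c1ccc(CO)cc1`, which differs from compound 3 by a single exchange (hydroxy in place of chloro on a saturated chain carbon bound to an aromatic carbon). This places hydroxy in place of chloro on a saturated chain carbon bound to an aromatic carbon.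

Among the measured compounds shown here, no measured pair isolates this exchange, and no measured compound carries hydroxy, so the size of the step is a judgement with wide bounds. Compound 2 (8400 nM) has no chloromethyl and sits well above compound 3, which suggests a loss of potency on leaving chloromethyl. Compound 1 (6900 nM) goes against that reading, since it keeps chloromethyl and still sits well above compound 3. In this assay a weakening beyond the scatter is therefore expected, though with low confidence.

The estimated step is an 8.9-fold higher number from compound 3 to compound 4 (0.95 log units; beyond the scatter) and points towards weaker inhibition. For compound 4 the expected value is 8000 nM with an estimated range from 2500 nM to 30000 nM.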

Compound 4, half-maximal inhibitory concentration: > 100000 nM
Compound 4: a limit, no number; the forecaster's own chance of this, stated with the estimate: 25%; middle value at least 12-fold (1.09 log units) from the limit.
By their numbers in this assay, from the lowest: compound 3; then compounds 1 and 2 (each within the scatter of the next). At a limit, above all of these: compound 4.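

In this assay, the series gains its first comparison that differs in one place: hydroxy in place of chloro on a saturated chain carbon bound to an aromatic carbon gives an at least 110-fold higher number from compound 3 to compound 4 (2.04 log units; beyond the scatter). Compound 4 gives > 100000 nM, which is a limit of the assay and not a number, so the step has a lower bound only: the limit of > 100000 nM in this assay, at which 1 of the 4 values shown sits. This position is therefore highly sensitive to the change from chloromethyl to hydroxymethyl, which compounds 1 and 2 could not show, as neither differs from compound 3 in one place only.

As far as these compounds go, whether the step follows from the loss of chloro or from the entry of hydroxy remains open, and a plain methyl, a methoxymethyl or a bromomethyl at the same place would help to separate these two readings. Also open, from the compounds shown here alone, is how an aminomethyl or a nitrooxymethyl group would read on the core of compound 3, and so whether chloromethyl is uniquely favoured there or hydroxymethyl is uniquely poor.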